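Losing one chloro on the aryl ring: expected inhibition

The source may report more compounds than this note shows. Statements on the series, on what has been measured and on what is new or still open speak of the compounds shown alone.

Of the compounds shown here, two have numbers so far. Compound 1 `COc1ccc(-c2ccc(=O)n(CCC(=N)S)n2)cc1` gives 20.7% in a functional assay on the whole organism (stomach) for inhibition, with Rattus norvegicus as the target, at a dose of 100 mg/kg by the intraduodenal route; on this read-out lower numbers stand for less inhibition and higher numbers for more inhibition at the one dose given (going by the name of the read-out). Compound 2 `N=C(S)CCn1nc(-c2ccc(Cl)c(Cl)c2)ccc1=O` gives 55.8% in this assay, the higher of the two numbers, standing above compound 1 by a gap beyond the usual scatter. Within the data shown here, no measured pair differs in only one place, so no single step is yet known. Compound 3 `N=C(S)CCn1nc(-c2ccc(Cl)cc2)ccc1=O` is the next compound for this assay. It differs from compound 2 thus: hydrogen in place of chloro on an aromatic carbon. One chloro group remains on the ring; the methoxy compound 1 sits far lower. The step is expected to run downward from compound 2, of moderate size, near the edge of the scatter. The expected step is a number 15.8 percentage points lower from compound 2 to compound 3 (beyond the scatter). For compound 3 the estimate is 40%, within a range from 20% to 60%.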

Compound 3, a percentage reported as inhibition, in the whole organism at one dose (the size of the read-out at that dose, not a potency): 42.5%
Estimate against measurement, compound 3: 2.5 percentage points below; the measured number falls inside the stated range.
By their numbers in this assay, from the lowest: compound 1; then compound 3; then compound 2.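

In this assay the chloro ortho to a chloro group and meta to a large group now has its first single-place reading (a number 13.3 percentage points lower from compound 2 to compound 3 (beyond the scatter)), so this second chloro counts in the series, and hydrogen on that aromatic carbon does not match it. Chloro in place of methoxy on an aromatic carbon also gets a reading (a number 21.8 percentage points higher from compound 1 to compound 3 (beyond the scatter)), which splits the wide gap between compound 1 and compound 2 into two single-place steps, both beyond the scatter. No measurement on hand gives a reason for either step.

Open, as far as these compounds go, is whether fluoro or trifluoromethyl on this aromatic carbon would track chloro or hydrogen. Also open, from the compounds shown here alone, is how the aryl ring with no chloro at all would read, and whether an amine or a carboxylic acid at the chain end would leave these steps intact.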